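Chain Lengthening on the Cyclic Phosphate Nucleoside Core

The compounds below may be only part of what the source reports. "The series", "measured", "known", "first", "only" and "open" are said of these compounds alone.

Compound 1 `CCc1cn([C@H]2C[C@@H]3OP(=O)(O)OC[C@H]3O2)c(=O)[nH]c1=O` — 55 ug/mL
Compound 2 `CCCCCc1cn([C@H]2C[C@H](O)[C@@H](CO)O2)c(=O)[nH]c1=O` — 476 ug/mL
Compound 3 `CCCCCCCCc1cn([C@H]2C[C@H](O)[C@@H](CO)O2)c(=O)[nH]c1=O` — 66 ug/mL

In a functional assay on L1210 cells (Mus musculus) (a higher number here means a weaker inhibitor, a lower number a stronger inhibitor), compound 1 gives 55 ug/mL, the lowest of the three numbers; compound 3 sits within the scatter of it, while compound 2 lies beyond the scatter with a higher number. Compound 4 `CCCCc1cn([C@H]2C[C@@H]3OP(=O)(O)OC[C@H]3O2)c(=O)[nH]c1=O` has not yet been measured in this assay. It differs from compound 1 by one change: ethyl in place of hydrogen on a saturated chain carbon, two bonds along the chain from an aromatic carbon. Within the data shown here, the one measured step that bears on a longer chain at this site is a 7.2-fold lower number from compound 2 to compound 3 (0.86 log units; beyond the scatter), a modest move toward a lower number, although it extends a longer chain on a different core. Taken with the standing of compound 1, a step of similar direction but uncertain size is expected here, and it may stay within the scatter. The estimated step is a 1.6-fold lower number from compound 1 to compound 4 (0.20 log units; within the scatter). Compound 4 is therefore expected to give about 35 ug/mL in this assay, with a range from 10 ug/mL to 150 ug/mL.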

Compound 4, concentration for 50% inhibition: 28.4 ug/mL
The estimate for compound 4 lay 1.2-fold (0.09 log units) above the measured number, within the range that was stated.
By their numbers in this assay, from the lowest: compounds 4, 1 and 3 (each within the scatter of the next, the first and the last beyond it); then compound 2.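

Measured directly on the core of compound 1, ethyl in place of hydrogen on a saturated chain carbon, two bonds along the chain from an aromatic carbon, gives in this assay a 1.9-fold lower number from compound 1 to compound 4 (0.29 log units; within the scatter), so the butyl chain of compound 4 cannot be told apart from the ethyl chain of compound 1. Among these compounds, the only earlier chain step, a 7.2-fold lower number from compound 2 to compound 3 (0.86 log units; beyond the scatter), lay beyond the scatter, but it was read on a different core and five bonds along the chain, so this is the first reading of chain length on the core of compound 1. Nothing available explains the result.

The compounds shown leave open whether a longer chain, such as hexyl or octyl, would move beyond the scatter on this core. They also leave open how an amine or a carboxylic acid at the end of the chain would read.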